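Pyridin-3-yl Ester in Place of Acetyl: Expected Cytotoxicity

A few compounds are considered here, and "the series" means these few. Any claim that something is new, unique, unknown or untested is made for them only; others in the source may bear on it.

Measured compounds:
Compound 1 `CC(=O)Oc1c(C(C)C)cc2c3c1OC(=O)[C@@]31CCCC(C)(C)[C@@H]1CC2` gives 294000 nM.
Compound 3 `CC(C)c1cc2c3c(c1OC(=O)c1ccccc1)OC(=O)[C@@]31CCCC(C)(C)[C@@H]1CC2` gives 510000 nM.
Compound 2 `CCCCCCCCCCCCCCCC(=O)Oc1c(C(C)C)cc2c3c1OC(=O)[C@@]31CCCC(C)(C)[C@@H]1CC2` is reported only as a limit, > 1000000 nM.

All three share one core and differ only in the ester group on the phenol oxygen. In an ADME assay on HepG2 cells (Homo sapiens) for cytotoxicity, read by neutral red uptake, with a stated time of 24 h (a lower number here means a stronger inhibitor, a higher number a weaker inhibitor), compound 1 gives 294000 nM, the lowest of the two numbers shown. Compound 3 gives 510000 nM, and the step of a 1.7-fold higher number from compound 1 to compound 3 (0.24 log units; within the scatter) lies within the scatter, so the two compounds cannot be ordered. For compound 2 the assay reports only a limit, > 1000000 nM, which is the limit of > 1000000 nM in this assay, at which 1 of the 3 values shown sits.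

Compound 4 `CC(C)c1cc2c3c(c1OC(=O)c1cccnc1)OC(=O)[C@@]31CCCC(C)(C)[C@@H]1CC2` differs from compound 1 by pyridin-3-yl in place of methyl on a carbonyl carbon. Among the compounds with values here, the only measured step that bears on this change is the exchange of methyl for phenyl at the same carbonyl carbon, a 1.7-fold higher number from compound 1 to compound 3 (0.24 log units; within the scatter), which stayed within the scatter. A similar outcome is therefore expected here: a 1.4-fold higher number from compound 1 to compound 4 (0.13 log units; within the scatter), no shift beyond the scatter in either direction. Compound 4 is estimated at 400000 nM, with a likely range from 150000 nM to 1000000 nM.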

Compound 4, half-maximal inhibitory concentration: 264000 nM
For compound 4 the middle estimate is 1.5-fold (0.18 log units) above the measured one, and the stated range covers the measured number.
By their numbers in this assay, from the lowest: compounds 4, 1 and 3 (each within the scatter of the next). At a limit, above all of these: compound 2.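

Putting a ring on the carbonyl carbon in place of methyl does not shift the reading in this assay: the change gives a 1.1-fold lower number from compound 1 to compound 4 (0.05 log units; within the scatter), so compound 1 and compound 4 cannot be ordered. The new compound also separates the effect of the ring from that of its nitrogen, since exchanging phenyl for pyridin-3-yl gives a 1.9-fold lower number from compound 3 to compound 4 (0.29 log units; within the scatter), and the added nitrogen, which brings a hydrogen-bond acceptor, therefore makes no readable difference here. Methyl, phenyl and pyridin-3-yl thus all read alike at this carbonyl carbon, and nothing shown offers a reason for that.

As far as these compounds go, whether an amine or a carboxylic acid on the ring would move the number beyond the scatter remains open. So does the question of how a chain of moderate length would read, as only the long chain of compound 2 is shown, and its value is a limit.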